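Sulfonate Adduct on a Second Core: Cytotoxicity Expectation

A few compounds are considered here, and "the series" means these few. Any claim that something is new, unique, unknown or untested is made for them only; others in the source may bear on it.

Measured compounds:
Compound 1 `CC(C)C[C@H](NC(=O)OC(Cc1ccccc1)C1CCC(F)(F)CC1)C(=O)N[C@H](C=O)C[C@@H]1CCNC1=O` gives > 100000 nM in this assay.
Compound 2 `CC(C)C[C@H](NC(=O)OC(Cc1ccccc1)C1CCC(F)(F)CC1)C(=O)N[C@@H](C[C@@H]1CCNC1=O)C(O)S(=O)(=O)O` gives > 100000 nM in this assay.
Compound 3 `CC(C)C[C@H](NC(=O)OC(c1ccccc1)C1CCC(F)(F)CC1)C(=O)N[C@H](C=O)C[C@@H]1CCNC1=O` gives > 100000 nM in this assay.

The read-out throughout is an ADME assay on HEK-293T cells (Homo sapiens) for cytotoxicity, with a stated time of 72 h; on this read-out lower numbers stand for higher toxicity in this test and higher numbers for lower toxicity in this test. Each of the three values above is a limit of the assay, not a number: the cells tolerated every compound up to the highest concentration tested. Compound 1 and compound 2 share one core and differ by hydroxy(sulfo)methyl in place of formyl on a saturated chain carbon bound to an amide-type nitrogen and a saturated chain carbon; the step between them is a step that the two limits leave unreadable from compound 1 to compound 2. Compound 1 and compound 3 differ in their cores by phenyl in place of benzyl on a saturated chain carbon bound to an oxygen next to a carbonyl group and a saturated ring carbon; that step is a step that the two limits leave unreadable from compound 1 to compound 3. No step can be read because all three values sit at the limit of > 100000 nM in this assay, at which 3 of the 3 values shown sit.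

Compound 4 `CC(C)C[C@H](NC(=O)OC(c1ccccc1)C1CCC(F)(F)CC1)C(=O)N[C@@H](C[C@@H]1CCNC1=O)C(O)S(=O)(=O)O` has not yet been measured. It differs from compound 3 by hydroxy(sulfo)methyl in place of formyl on a saturated chain carbon bound to an amide-type nitrogen and a saturated chain carbon, the same change that turns compound 1 into compound 2, at the same place, word for word. For compound 4 the step expected in this assay is a step that the limit leaves unreadable from compound 3 to compound 4. This expectation rests on compound 2, whose value > 100000 nM is a limit, and on (the limit of > 100000 nM in this assay, at which 3 of the 3 values shown sit). The most likely outcome for compound 4 is another limit rather than a number. The estimate for compound 4 is 150000 nM, within a range from 50000 nM to 500000 nM.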

Compound 4, half-maximal cytotoxic concentration: > 100000 nM
Compound 4 was reported as a limit (the forecaster's own chance of this, stated with the estimate: 85%); the middle value does not contradict the limit.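

In this assay compound 4 gives > 100000 nM as a limit of the assay, not a number. The steps to compound 4 from compound 3 and from compound 2 therefore cannot be read, because all the values sit at one limit: the limit of > 100000 nM in this assay, at which 4 of the 4 values shown sit.

The compounds shown leave open whether swapping formyl for hydroxy(sulfo)methyl, or benzyl for phenyl, changes the result in this assay at concentrations past that limit.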